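A few compounds are considered here, and "the series" means these few. Any claim that something is new, unique, unknown or untested is made for them only; others in the source may bear on it.

Compound 1 `O=[N+]([O-])c1ccc(CN2CCC(n3cc(CC(OCc4cc(-c5cccc(F)c5)no4)c4ccc(Br)cc4)nn3)CC2)cc1` gives 6000 nM in a functional assay on HCT-116 cells (Homo sapiens) for cytotoxicity, with a stated time of 48 h; a higher number here means a weaker inhibitor, a lower number a stronger inhibitor. Compound 2 `COc1cccc(-c2cc(COC(Cc3cn(C4CCN(Cc5ccc([N+](=O)[O-])cc5)CC4)nn3)c3ccc(Br)cc3)on2)c1` gives only a limit, > 25000 nM, in this assay.

Compound 2 thus sits at the weak end of the two numbers shown; its one measured step, an at least 4.1-fold higher number from compound 1 to compound 2 (0.61 log units; beyond the scatter), is the whole record, and it runs up to the limit of > 25000 nM in this assay, at which 1 of the 2 values shown sits. Compound 3 `COc1ccccc1-c1cc(COC(Cc2cn(C3CCN(Cc4ccc([N+](=O)[O-])cc4)CC3)nn2)c2ccc(Br)cc2)on1` differs from compound 2 by 2-methoxyphenyl in place of 3-methoxyphenyl on an aromatic carbon. For the measured compounds named here, no measured step shifts the methoxy between ring positions, so no direction can be read from the data; the step from compound 2 is expected at a number no higher from compound 2 to compound 3 (the limit leaves the size open), nothing beyond the scatter. Compound 3 is therefore estimated at 25000 nM (range 7000 nM to 90000 nM), quite possibly again a limit.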

Compound 3, half-maximal inhibitory concentration: > 25000 nM
Compound 3 was reported as a limit (the forecaster's own chance of this, stated with the estimate: 60%); the middle value sits exactly at the limit.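

Moving the methoxy to give 2-methoxyphenyl yields no readable value in this assay: compound 3 gives > 25000 nM, which is a limit. The step between the two methoxy isomers cannot be read, so neither placement can be ranked, but 2-methoxyphenyl also stands apart from 3-fluorophenyl, with an at least 4.1-fold higher number from compound 1 to compound 3 (0.61 log units; beyond the scatter). The methoxy compounds now share one ceiling: the limit of > 25000 nM in this assay, at which 2 of the 3 values shown sit.

Still open, as far as these compounds go, is whether this gap is specific to methoxy. A plain phenyl, or a chloro or hydroxy group on this phenyl ring, would show how far other replacements for the fluoro follow it.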